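The source may hold more compounds than are shown below. What is called first, only, known or untested is meant among the compounds shown, and "the series" means these compounds.

In a functional assay on Raji cells (Homo sapiens) for cytotoxicity, with a stated time of 72 h (on this read-out higher numbers stand for weaker inhibition and lower numbers for stronger inhibition), compound 2 `CCOC(=O)/C=C/C=C/C=C/C=C/c1ccc[nH]1` gives 4090 nM and compound 3 `O=C(/C=C/C=C/C=C/c1ccc[nH]1)c1ccccc1` gives 9890 nM. Compound 3 therefore holds the higher of these two numbers, which means weaker inhibition, and the gap between them is larger than the usual scatter. Compound 1 `CCOC(=O)/C=C/C=C/C=C/c1ccc[nH]1` reads > 10000 nM, which is a limit of the assay and not a number.

Compound 4 `O=C(/C=C/C=C/C=C/C=C/c1ccc[nH]1)c1ccccc1` has not yet been measured. In it, 2-(1H-pyrrol-2-yl)ethenyl stands in place of 1H-pyrrol-2-yl on a double-bonded chain carbon bound to a double-bonded chain carbon (2-(1H-pyrrol-2-yl)ethenyl in place of 1H-pyrrol-2-yl on a double-bonded chain carbon bound to a double-bonded chain carbon).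

Going by the values given here, the one measured step available is a number no higher from compound 1 to compound 3 (the limit leaves the size open). Going by these compounds, it concerns the group on the carbonyl carbon rather than this change, and its size stays open, so it offers only weak guidance. The pair of compound 1 and compound 2 gives a further hint. The value of compound 1 is a limit of the assay. Compound 2 gives 4090 nM, a measured number. On that slender basis, a modest move toward stronger inhibition is expected, although it may not clear the scatter by much. The estimated change is a 2.6-fold lower number from compound 3 to compound 4 (0.42 log units; beyond the scatter). For compound 4, the expected value is 3800 nM, with an estimated range of 1300 nM to 9500 nM.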

Compound 4, half-maximal inhibitory concentration: 5990 nM
Compound 4: middle estimate off by 1.6-fold (0.20 log units), on the low side; the range from low to high includes it.
By their numbers in this assay, from the lowest: compounds 2, 4 and 3 (each within the scatter of the next, the first and the last beyond it). At a limit, above all of these: compound 1.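

In this assay, putting 2-(1H-pyrrol-2-yl)ethenyl in place of 1H-pyrrol-2-yl on a double-bonded chain carbon bound to a double-bonded chain carbon gives a 1.7-fold lower number from compound 3 to compound 4 (0.22 log units; within the scatter). With phenyl on the carbonyl carbon, this extra double bond therefore does not move the read-out beyond what repeated measurements would be expected to scatter. The second new step, with phenyl in place of ethoxy on a carbonyl carbon, gives a 1.5-fold higher number from compound 2 to compound 4 (0.17 log units; within the scatter), so on the longer chain these two groups cannot be told apart, while the size of the same swap on the shorter chain cannot be read: the same change on two cores in this assay, a number no higher (the limit leaves the size open) from compound 1 to compound 3 and a 1.5-fold higher number (0.17 log units; within the scatter) from compound 2 to compound 4; the limit leaves it open whether they differ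

Compound 1 reads > 10000 nM, which is a limit and not a number, so how much the extra double bond matters with ethoxy on the carbonyl carbon stays open: the limit of > 10000 nM in this assay, at which 1 of the 4 values shown sits. The compounds shown also leave open whether an amine or a carboxylic acid on the carbonyl carbon, or a still longer chain, would shift the number beyond the scatter.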